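The compounds below may be only part of what the source reports. "The series", "measured", "known", "first", "only" and "open" are said of these compounds alone.

Of the compounds shown here, three have so far been measured in an assay on isolated protein for agonist activity at melatonin receptor type 1C (Xenopus laevis), read by spectrophotometry; a higher number here means a larger maximal response, a lower number a smaller maximal response. Compound 1, `CCC(=O)NCc1ccc(OC)c(F)c1`, gives 51% in this assay. Compound 2, `CCCC(=O)NCc1ccc(OC)c(F)c1`, differs from compound 1 by a single change, (methyl in place of hydrogen on a saturated chain carbon, two bonds along the chain from a carbonyl carbon), and in this assay compound 2 gives 57%. The resulting step, a number 6 percentage points higher from compound 1 to compound 2 (within the scatter), is too small to count as a real difference between the two. Compound 3, `CCC(=O)NCc1ccc(F)c(OC)c1`, is built from the same atoms as compound 1, joined differently; the difference between the two cores is not broken down here. In this assay compound 3 gives 86%, the highest of the three, and its gaps to compound 1 and to compound 2 both lie beyond the scatter.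

Compound 4, `CCCC(=O)NCc1ccc(F)c(OC)c1`, has not yet been measured. It differs from compound 3 by methyl in place of hydrogen on a saturated chain carbon, two bonds along the chain from a carbonyl carbon, the same change that separates compound 1 from compound 2; among these compounds the change occurs twice. On the core of compound 1 it moved the maximal response by a number 6 percentage points higher from compound 1 to compound 2 (within the scatter), a step within the scatter. Going by the values given here, the same behaviour is expected on the core of compound 3, with a step of about a number 2 percentage points higher from compound 3 to compound 4 (within the scatter), because the single earlier example of this change gave a number 6 percentage points higher from compound 1 to compound 2 (within the scatter). Compound 4 is therefore estimated to reach 88% in this assay, most likely somewhere between 72% and 100%.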

Compound 4, largest response reached (reported as efficacy), in percent of the reference or control that the assay uses: 75%
For compound 4 the middle estimate is 13 percentage points above the measured one; measured number inside the range.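

On the core of compound 3, methyl in place of hydrogen on the chain carbon gives a number 11 percentage points lower from compound 3 to compound 4 (beyond the scatter) in this assay and that step counts as modest. The same change therefore does not carry over unchanged from one core to the other, and its step on the core of compound 1 was a poor guide to its step on the core of compound 3: the same change on two cores in this assay, a number 6 percentage points higher (within the scatter) from compound 1 to compound 2 and a number 11 percentage points lower (beyond the scatter) from compound 3 to compound 4, 17 percentage points apart, beyond the scatter of two such steps

Going by these compounds alone, this does not show why the two cores answer differently, and with only one pair on each core it gives no general rule for the series or any way to tell how the change would behave on a further core.

Going by these compounds, it remains open how a longer chain, a branched chain or a cyclopropyl group in place of the propylcarbonyl chain would act on these two cores, and whether the maximal response would keep falling on the core of compound 3 as the chain grows. Equally open, on these data alone, is whether chlorine in place of the fluorine, or ethoxy in place of the methoxy, would shift the maximal response or alter what the chain change does.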